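Swapping Chloro for Nitro in a Weak Cell-Growth Inhibitor

The source may hold more compounds than are shown below. What is called first, only, known or untested is meant among the compounds shown, and "the series" means these compounds.

Measured so far:
Compound 2 `O=c1ccc2cc(OCc3cc(-c4cccc5ccccc45)no3)ccc2o1`: 47200 nM
Compound 3 `O=c1ccc2cc(OCc3cc(-c4cccc(Cl)c4)no3)ccc2o1`: 32500 nM
Compound 1 `O=c1ccc2cc(OCc3cc(-c4ccccc4Cl)no3)ccc2o1`: "not determined" (no result reported)

In a functional assay on COLO 205 cells (Homo sapiens) for cytotoxicity, read by MTT assay, with a stated time of 48 h (on this read-out higher numbers stand for weaker inhibition and lower numbers for stronger inhibition), compound 3 stands at 32500 nM. Within the data shown here, the only other number comes from compound 2, which gives 47200 nM, and the gap between them lies within the usual scatter, so the two count as alike. Compound 1 has no result in this assay.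

Compound 4 `O=c1ccc2cc(OCc3cc(-c4cccc([N+](=O)[O-])c4)no3)ccc2o1` differs from compound 3 by nitro in place of chloro on an aromatic carbon. Among the measured compounds shown here, no measured pair shows this kind of change, so there is nothing beyond the two numbers to lean on. The step from compound 3 to compound 4 is expected to be a 1.1-fold lower number from compound 3 to compound 4 (0.03 log units; within the scatter), none beyond the scatter. Compound 4 is therefore estimated at 30000 nM, with a range from 12000 nM to 80000 nM.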

Compound 4, half-maximal inhibitory concentration: 48300 nM
Compound 4: middle estimate off by 1.6-fold (0.21 log units), on the low side; low and high end bracket the measured number.
By their numbers in this assay, from the lowest: compounds 3, 2 and 4 (each within the scatter of the next).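

In this assay nitro in place of chloro on this aromatic carbon gives a 1.5-fold higher number from compound 3 to compound 4 (0.17 log units; within the scatter) and so the two compounds count as alike. Among these compounds, this is the first measured pair that differs in one place, and it shows that a single chlorine atom and a nitro group with its three heavy atoms read the same here. Among the compounds shown here, nothing measured so far explains this likeness.
Going by these compounds, whether an amine or a carboxylic acid on this same carbon would read differently remains open. So does whether any group here can give a clearly lower number than compound 3 does.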